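From chloro to iodo: a small solubility question

This account rests on a few compounds, and the source may have more. Where it says the series, first, only, none or still open, it means among the compounds named here.

Compound 1 `CCc1ccc(-c2nc3c(c(C)nn3-c3ccccc3)c(-c3ccccc3O)c2C#N)cc1` gives 3100 nM
Compound 2 `Cc1nn(-c2ccccc2)c2nc(-c3ccc(C(F)(F)F)cc3)c(C#N)c(-c3ccccc3O)c12` gives 3500 nM
Compound 3 `Cc1nn(-c2ccccc2)c2nc(-c3ccc(Cl)cc3)c(C#N)c(-c3ccccc3O)c12` gives 3800 nM

These three compounds share one core and differ only in a single group on an aromatic carbon. In a physicochemical assay for solubility, read by spectrophotometry, in phosphate buffer, with a stated time of 18 h, at pH 7.4 (a lower number here means a less soluble compound, a higher number a more soluble compound), compound 3 gives 3800 nM as its reading, and this reading lies within the usual scatter of the other two, so the three cannot be ranked.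

Compound 4 `Cc1nn(-c2ccccc2)c2nc(-c3ccc(I)cc3)c(C#N)c(-c3ccccc3O)c12` has not been measured yet. It differs from compound 3 by one change: iodo in place of chloro on an aromatic carbon with iodo in place of chloro on an aromatic carbon, para to a large group.

Each of the three exchanges already measured at this place stayed small, with a 1.1-fold higher number from compound 1 to compound 2 (0.05 log units; within the scatter) for trifluoromethyl in place of ethyl, a 1.2-fold higher number from compound 1 to compound 3 (0.09 log units; within the scatter) for chloro in place of ethyl and a 1.1-fold higher number from compound 2 to compound 3 (0.04 log units; within the scatter) for chloro in place of trifluoromethyl. Among the compounds with values here, this evidence rests on only three compounds, and none of them carries iodo, so the range has to stay wide. In this assay no step beyond the scatter is expected, and the estimated step is a 1.2-fold lower number from compound 3 to compound 4 (0.06 log units; within the scatter) in size. For compound 4 the estimate is 3300 nM with an expected range from 1600 nM to 6000 nM for this measure of solubility.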

Compound 4, solubility: 1500 nM
Estimate against measurement, compound 4: 2.2-fold (0.34 log units) above; the whole stated range lies above it.
By their numbers in this assay, from the lowest: compound 4; then compounds 1, 2 and 3 (each within the scatter of the next).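

In this assay, the place para to a large group had seemed tolerant, since ethyl, trifluoromethyl and chloro gave readings within the scatter of one another. Iodo is the first group here to stand apart: exchanging chloro for it gives a 2.5-fold lower number from compound 3 to compound 4 (0.40 log units; beyond the scatter) and exchanging trifluoromethyl for it gives a 2.3-fold lower number from compound 2 to compound 4 (0.37 log units; beyond the scatter) while exchanging ethyl for it gives a 2.1-fold lower number from compound 1 to compound 4 (0.32 log units; beyond the scatter) and each of these steps is modest yet beyond the scatter. This change swaps one heavy atom for one heavy atom, with no ring, hydrogen-bond donor, hydrogen-bond acceptor or net charge entering or leaving, so these simple counts do not tell iodo from chloro.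

Nothing shown here explains the lower reading of compound 4.

Also open, on these data alone, is whether bromo, an amine or a carboxylic acid at this place would read with compounds 1, 2 and 3 or with compound 4, and whether iodo would give a similar step on a different core.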